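This account rests on a few compounds, and the source may have more. Where it says the series, first, only, none or still open, it means among the compounds named here.

Of the compounds shown here, three of one shared core have been measured in an assay for inhibition of high affinity nerve growth factor receptor (Homo sapiens), read by HTRF, with a stated time of 30 min, in the presence of a further agent that is not named here; a higher number here means a weaker inhibitor, a lower number a stronger inhibitor. Compound 1 `Cc1cc(Nc2nc(NCc3ccc(F)cc3)nc3ccccc23)n[nH]1` gives 20 nM, compound 2 `Cc1cc(Nc2nc(NCc3ccc(Cl)cc3)nc3ccccc23)n[nH]1` gives 380 nM and compound 3 `Cc1cc(Nc2nc(NCc3c(F)cccc3F)nc3ccccc23)n[nH]1` gives 160 nM. Compound 3 thus stands second highest of the three: the step of an 8.0-fold higher number from compound 1 to compound 3 (0.90 log units; beyond the scatter) is modest, and the step of a 2.4-fold lower number from compound 2 to compound 3 (0.38 log units; beyond the scatter) is modest as well. Compound 4 `Cc1cc(Nc2nc(NCc3cc(F)cc(F)c3)nc3ccccc23)n[nH]1` differs from compound 3 by 3,5-difluorophenyl in place of 2,6-difluorophenyl on a saturated chain carbon bound to a nitrogen on an aromatic ring. Within the data shown here, no measured pair shows this change; the two steps above move the fluorophenyl pattern, not the ring positions alone, and both stayed within about one order. A step of no size beyond the scatter is therefore expected, a 1.1-fold lower number from compound 3 to compound 4 (0.03 log units; within the scatter). Compound 4 is estimated at 150 nM in this assay, with a likely range from 50 nM to 500 nM.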

Compound 4, half-maximal inhibitory concentration: 170 nM
Beside the measured number, compound 4's estimate is 1.1-fold (0.05 log units) below it; low and high end bracket the measured number.
By their numbers in this assay, from the lowest: compound 1; then compounds 3 and 4 (each within the scatter of the next); then compound 2.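

In this assay, the 2,6-difluorophenyl and 3,5-difluorophenyl groups on this saturated chain carbon cannot be told apart, with a 1.1-fold higher number from compound 3 to compound 4 (0.03 log units; within the scatter). Compound 4 stands apart from the two monosubstituted phenyl compounds, with an 8.5-fold higher number from compound 1 to compound 4 (0.93 log units; beyond the scatter) and a 2.2-fold lower number from compound 2 to compound 4 (0.35 log units; beyond the scatter), so among these compounds only the 4-fluorophenyl group of compound 1 gives a number far below the rest. No evidence is at hand that accounts for these results. Going by these compounds, it remains open how 4-methoxyphenyl or 3-fluorophenyl would stand at this place. On these data alone, whether a longer chain carrying the 4-fluorophenyl group would hold the number of compound 1 also remains open.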